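This account rests on a few compounds, and the source may have more. Where it says the series, first, only, none or still open, it means among the compounds named here.

Three compounds sharing one core have numbers in an in vitro ADME assay on microsomes from liver (Homo sapiens) for pharmacokinetics, read by LC-MS, with a stated time of 10 min, tested at 1 uM; a lower number here means slower removal, a higher number faster removal of the compound. Compound 1 `CC(C)(C)N1C[C@H](C(=O)Nc2ccc(Cl)cc2)[C@@H](c2ccc(/C=C/C(=O)Nc3ccccc3N)cc2)C1`, with tert-butyl on an amine nitrogen in a ring, gives 8 mL/min/kg. Compound 2 `CCNC(=O)N1C[C@H](C(=O)Nc2ccc(Cl)cc2)[C@@H](c2ccc(/C=C/C(=O)Nc3ccccc3N)cc2)C1`, with ethylcarbamoyl at that place, gives 9 mL/min/kg, and the step between them is a 1.1-fold higher number from compound 1 to compound 2 (0.05 log units; within the scatter). Compound 3 `CCN(CC)C(=O)N1C[C@H](C(=O)Nc2ccc(Cl)cc2)[C@@H](c2ccc(/C=C/C(=O)Nc3ccccc3N)cc2)C1`, with diethylcarbamoyl there, stands highest of the three at 19 mL/min/kg.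

Compound 4 `Nc1ccccc1NC(=O)/C=C/c1ccc([C@H]2CN(c3ncccn3)C[C@@H]2C(=O)Nc2ccc(Cl)cc2)cc1` has pyrimidin-2-yl in place of diethylcarbamoyl on an amine nitrogen in a ring. Within the data shown here, no measured compound carries an aromatic ring at this place, so the guidance is indirect. The two steps that lead to compound 3 are a 2.1-fold higher number from compound 2 to compound 3 (0.32 log units; beyond the scatter) and a 2.4-fold higher number from compound 1 to compound 3 (0.38 log units; beyond the scatter), and both bring in the diethylcarbamoyl group that now leaves. A move back toward the lower numbers in this assay is therefore expected, smaller than those two steps. The expected change is a 1.6-fold lower number from compound 3 to compound 4 (0.20 log units; within the scatter). For compound 4 the estimated clearance is 12 mL/min/kg, with an expected range from 6 mL/min/kg to 26 mL/min/kg.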

Compound 4, clearance: 11 mL/min/kg
Beside the measured number, compound 4's estimate is 1.1-fold (0.04 log units) above it, and the stated range covers the measured number.
By their numbers in this assay, from the lowest: compounds 1, 2, 4 and 3 (each within the scatter of the next, the first and the last beyond it).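

In this assay, among these compounds, the amine nitrogen in the ring now carries an aromatic ring, a kind of group absent from the earlier compounds, and exchanging diethylcarbamoyl for pyrimidin-2-yl gives (a 1.7-fold lower number from compound 3 to compound 4 (0.24 log units; within the scatter)). Set against the other two groups, pyrimidin-2-yl gives (a 1.2-fold higher number from compound 2 to compound 4 (0.09 log units; within the scatter)) and (a 1.4-fold higher number from compound 1 to compound 4 (0.14 log units; within the scatter)), so compound 4 cannot be told apart from any of the three, even though compound 1 and compound 3 lie beyond the scatter of each other. No measurement at hand accounts for this result. Going by these compounds, with a single aromatic ring at this place, it remains open whether phenyl, which has no ring nitrogen, or pyridin-2-yl, which has one, would give similar numbers. Also open, on these data alone, is how a carboxylic acid or a longer chain ending in an amine would behave here.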